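The source may report more compounds than this note shows. Statements on the series, on what has been measured and on what is new or still open speak of the compounds shown alone.

Measured compounds:
Compound 1, `O=C(O)c1ccccc1-c1ccc(CCc2ncc(CC3CCCCC3)[nH]2)cc1`: 7.3 nM
Compound 2, `CCCCc1cnc(C(C)Cc2ccc(-c3ccccc3C(=O)O)cc2)[nH]1`: 184 nM
Compound 3, `CCCCc1cnc(CCCc2ccc(-c3ccccc3C(=O)O)cc2)[nH]1`: 382 nM

These three compounds share a core and were tested in an in vitro functional assay on cells for agonist activity at Bombesin receptor subtype-3 (Mus musculus), read by luminescence and calcium flux; a higher number here means that more compound is needed for the effect, a lower number that less compound is needed. Compound 1 gives the lowest of the three numbers, 7.3 nM, so it needs the least compound for the effect. Compound 2 and compound 3 both give clearly higher numbers, and each of those gaps lies beyond the scatter of repeated measurements, so compound 1 is the most potent of the three.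

Compound 4, `O=C(O)c1ccccc1-c1ccc(CCc2ncc(CC3CCCC3)[nH]2)cc1`, has not been measured yet. It is built from compound 1 by a single change: cyclopentyl in place of cyclohexyl on a saturated chain carbon bound to an aromatic carbon. Nothing else in the molecule moves. Among the measured compounds shown here, no pair among the measured compounds shows this particular change, so there is no measured step to lean on; the only guide is that compound 1 itself sits at 7.3 nM and that the change is a small one in the size of a saturated ring.

The expectation is therefore for a step of modest size, if any, most likely a slight rise in the number, and possibly none beyond the scatter. This amounts to an expected step of a 1.8-fold higher number from compound 1 to compound 4 (0.25 log units; within the scatter) in this assay. For compound 4 the estimated value is 13 nM, with a range from 4 nM to 45 nM.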

Compound 4, half-maximal effective concentration: 7.9 nM
For compound 4 the middle estimate is 1.6-fold (0.22 log units) above the measured one; low and high end bracket the measured number.
By their numbers in this assay, from the lowest: compounds 1 and 4 (each within the scatter of the next); then compound 2; then compound 3.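

In this assay, the step at this position reads a 1.1-fold higher number from compound 1 to compound 4 (0.03 log units; within the scatter) and lies within the scatter, so cyclohexyl and cyclopentyl on a saturated chain carbon bound to an aromatic carbon cannot be told apart by this read-out. Among the compounds shown here, the earlier compounds contained no pair differing in one place, so this is the first direct comparison at this position, and it shows that a ring of five heavy atoms and a ring of six give matching results in this one pair, on the core of compound 1. Nothing measured among the compounds shown bears on why the two rings read alike.

What the compounds shown leave open is how far this match extends to other groups at the same place, such as a smaller cyclopropyl ring, a larger cycloheptyl ring, an aromatic phenyl ring, or a cyclohexyl ring carrying a hydroxyl group or an amine. Going by these compounds, it is also open whether cyclopentyl and cyclohexyl would still match if another part of the shared core were altered, since this single pair speaks only for the core of compound 1.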